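Nitro to Chloro on the Benzamide Ring of a Shared Core

The source may hold more compounds than are shown below. What is called first, only, known or untested is meant among the compounds shown, and "the series" means these compounds.

Measured so far:
Compound 1, `COc1ccc(CNC(=O)CSc2nc3ccc(NC(=O)c4ccc(Cl)cc4)cc3s2)cc1`, in a functional assay on HepG2 cells (Homo sapiens) for cytotoxicity, read by MTT assay, with a stated time of 48 h; on this read-out higher numbers stand for weaker inhibition and lower numbers for stronger inhibition: 7400 nM
Compound 2, `O=C(CSc1nc2ccc(NC(=O)c3ccc(Cl)cc3)cc2s1)NCc1ccc(Cl)cc1`: 17800 nM
Compound 3, `O=C(CSc1nc2ccc(NC(=O)c3ccc([N+](=O)[O-])cc3)cc2s1)NCc1ccccc1`: > 100000 nM

Compound 3 is known in this assay only as a limit, not a number; it sits at the limit of > 100000 nM in this assay, at which 1 of the 3 values shown sits. Compound 4, `O=C(CSc1nc2ccc(NC(=O)c3ccc(Cl)cc3)cc2s1)NCc1ccccc1`, differs from it by chloro in place of nitro on an aromatic carbon. Within the data shown here, no measured step covers this exchange. Among the measured compounds shown here, the single measured step, a 2.4-fold higher number from compound 1 to compound 2 (0.38 log units; beyond the scatter), concerns the other aromatic ring and is modest. Compound 1 gives 7400 nM and compound 2 gives 17800 nM, and both carry the same (4-chlorophenyl)carbonyl group as compound 4. On that basis compound 4 is expected to fall near those two, estimated at 15000 nM with a range from 4000 nM to 80000 nM. The estimated step is an at least 6.6-fold lower number from compound 3 to compound 4 (0.82 log units; beyond the scatter).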

Compound 4, half-maximal inhibitory concentration: 25400 nM
The estimate for compound 4 lay 1.7-fold (0.23 log units) below the measured number; the measured number falls inside the stated range.
By their numbers in this assay, from the lowest: compound 1; then compounds 2 and 4 (each within the scatter of the next). At a limit, above all of these: compound 3.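

In this assay, among these compounds, the exchange of 4-nitrophenyl for 4-chlorophenyl gives an at least 3.9-fold lower number from compound 3 to compound 4 (0.59 log units; beyond the scatter), the first measured step at this position. Compound 3 stands only as a limit, so this step has no exact size: the limit of > 100000 nM in this assay, at which 1 of the 4 values shown sits. On the other aromatic ring, with the (4-chlorophenyl)carbonyl group held constant, hydrogen in place of chloro gives a 1.4-fold higher number from compound 2 to compound 4 (0.15 log units; within the scatter), whereas hydrogen in place of methoxy gives a 3.4-fold higher number from compound 1 to compound 4 (0.54 log units; beyond the scatter).

On these data alone, whether the nitro-to-chloro step holds with methoxy or chloro on that other ring stays open. Also open, as far as these compounds go, is what an amine or a carboxylic acid would give in place of the chloro.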